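The source may hold more compounds than are shown below. What is called first, only, known or untested is meant among the compounds shown, and "the series" means these compounds.

Compound 1 `COc1ccc(/C=C/C(=O)c2ccccc2-c2ccc(OC)c(OC)c2)cc1` and compound 2 `COc1ccc(/C=C/C(=O)c2ccccc2-c2ccc(OC)c(OC)c2)cc1OC` share one core and differ by a single change, (methoxy in place of hydrogen on an aromatic carbon). In a functional assay on HepG2 cells (Homo sapiens) for antiproliferative activity, read by sulforhodamine B assay, with a stated time of 48 h (a higher number here means a weaker inhibitor, a lower number a stronger inhibitor), compound 1 gives 600 nM, while compound 2 gives 3200 nM, a step of a 5.3-fold higher number from compound 1 to compound 2 (0.73 log units; beyond the scatter). Compound 3 `COc1ccc(C(=O)/C=C/c2ccccc2-c2ccc(F)cc2)cc1` is built on a different core; the difference between the two cores is not broken down here. In this assay compound 3 gives 6300 nM, the highest of the three numbers, within the scatter of compound 2 but well apart from compound 1. Compound 4 `COc1ccc(C(=O)/C=C/c2ccccc2-c2ccc(F)cc2)cc1OC` carries the same change, (methoxy in place of hydrogen on an aromatic carbon), applied to compound 3. Because the step of a 5.3-fold higher number from compound 1 to compound 2 (0.73 log units; beyond the scatter) was a weakening, compound 4 is expected to be weaker than compound 3 by roughly a 4.0-fold higher number from compound 3 to compound 4 (0.60 log units; beyond the scatter), giving an estimated value near 25000 nM, between 8000 nM and 80000 nM.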

Compound 4, half-maximal inhibitory concentration: 6600 nM
Compound 4: the middle estimate sits 3.8-fold (0.58 log units) above what was measured; the measured number lies below the stated range.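

In this assay, placing the methoxy on the core of compound 3 gives a 1.0-fold higher number from compound 3 to compound 4 (0.02 log units; within the scatter), so on this core the change has no readable effect. The clear weakening seen on the core of compound 1 therefore did not carry over to the core of compound 3: the same change on two cores in this assay, a 5.3-fold higher number (0.73 log units; beyond the scatter) from compound 1 to compound 2 and a 1.0-fold higher number (0.02 log units; within the scatter) from compound 3 to compound 4, 5.1-fold (0.71 log units) apart, beyond the scatter of two such steps

This shows that, across these two pairs, the result of the change depends on the core, but it does not show which difference between the cores is responsible, or how other cores would behave.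

Going by these compounds, it remains open whether a hydroxyl, an amine or a longer chain such as ethoxy, placed on the same aromatic carbon, would also give different results on the two cores.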